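Swapping an oxadiazole for thiophene in a urea series

The source may hold more compounds than are shown below. What is called first, only, known or untested is meant among the compounds shown, and "the series" means these compounds.

Compound 1, `Cc1cc(C)c(NC(=O)N(Cc2ccc(-c3nnc(C)o3)cc2)C2CCCCCC2)c(C)c1`: in a functional assay on a cell-free system (plasma) with sterol O-acyltransferase, Soat (Rattus norvegicus) as the target (on this read-out higher numbers stand for an effect only at larger amounts of compound and lower numbers for an effect already at smaller amounts), compound 1 gives > 0.32 mg/kg.
Compound 2, `O=C(Nc1c(F)cc(F)cc1F)N(Cc1cccc(-c2cc[nH]n2)c1)C1CCCCCC1`: in this assay compound 2 gives 0.062 mg/kg.
Compound 3, `Cc1cc(C)c(NC(=O)N(Cc2cccc(-c3cc[nH]n3)c2)C2CCCCC2)c(C)c1`: in this assay compound 3 gives 0.12 mg/kg.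

The value of compound 1 is a limit of the assay, not a number: the limit of > 0.32 mg/kg in this assay, at which 1 of the 3 values shown sits. Compound 2 and compound 3 each show a number, and both of those numbers lie below the limit at which compound 1 sits. Among the compounds with values here, none of these three compounds differs from another in just one place, so no single step between measured compounds can be read from them.

The new compound 4, `Cc1cc(C)c(NC(=O)N(Cc2ccc(-c3cccs3)cc2)C2CCCCCC2)c(C)c1`, is built from compound 1 by one change: thiophen-2-yl in place of 5-methyl-1,3,4-oxadiazol-2-yl on an aromatic carbon. Within the data shown here, for this change there is no measured pair to lean on, and compound 1 itself only marks a limit, so the direction of the step in this assay cannot be taken from the data. The expectation is therefore a step of modest size from compound 1 to compound 4, an at least 1.0-fold lower number from compound 1 to compound 4 (0.02 log units; that floor lies within the scatter), with a wide band around it, and a real chance that compound 4 again reaches only a limit. For compound 4 in this assay a dose of about 0.3 mg/kg is estimated, within a range from 0.08 mg/kg to 1 mg/kg.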

Compound 4, dose for half-maximal effect: 0.28 mg/kg
For compound 4 the middle estimate is 1.1-fold (0.03 log units) above the measured one, and the stated range covers the measured number.
By their numbers in this assay, from the lowest: compounds 2 and 3 (each within the scatter of the next); then compound 4. At a limit, above all of these: compound 1.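

Replacing 5-methyl-1,3,4-oxadiazol-2-yl with thiophen-2-yl on the six-membered aromatic ring, para to a large group, gives in this assay an at least 1.1-fold lower number from compound 1 to compound 4 (0.05 log units; that floor lies within the scatter). Compound 1 stands at a limit of the assay and not at a number: the limit of > 0.32 mg/kg in this assay, at which 1 of the 4 values shown sits.

Compound 4 gives 0.28 mg/kg. Within the data shown here, this position, which until now had only a limit to show, now has a true number, reached with a ring holding a single hetero atom in place of one holding three; the printed floor of the step stays within the scatter, so the data show no real gain from the change, only that the swap does not push the compound out of the measurable range.

Going by these compounds, what compound 1 would read as a true number remains open, and with it the real size of this step. Also open, on these data alone, is how other groups at this same place would read, such as a plain phenyl ring, a carboxylic acid or an amine, and whether any of them would give a number clearly beyond the scatter from that of compound 4.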